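Series notes: from compound 3 to compound 4

A few compounds are considered here, and "the series" means these few. Any claim that something is new, unique, unknown or untested is made for them only; others in the source may bear on it.

In a functional assay on MCF7 cells (Homo sapiens) for cytotoxicity, read by MTT assay, with a stated time of 24 h, tested at 32 ug/mL (on this read-out lower numbers stand for a weaker effect and higher numbers for a stronger effect at the one concentration tested), compound 3 `Cn1ccnc1SCC(=O)Nc1ccc(-c2nc(-c3ccccc3)c(-c3ccccc3)n2C)cc1` gives 43.4%, the second highest of the three numbers. Compound 1 `Cn1c(-c2ccc(NC(=O)CCl)cc2)nc(-c2ccccc2)c1-c1ccccc1` gives 42.8% and compound 2 `Cc1nnc(SCC(=O)Nc2ccc(-c3nc(-c4ccccc4)c(-c4ccccc4)n3C)cc2)s1` gives 83.4%; the step of a number 0.6 percentage points higher from compound 1 to compound 3 (within the scatter) is within the scatter, while the step of a number 40 percentage points lower from compound 2 to compound 3 (beyond the scatter) is large. Compound 4 `CN(C)/C=C/N1CCN(CC(=O)Nc2ccc(-c3nc(-c4ccccc4)c(-c4ccccc4)n3C)cc2)CC1` differs from compound 3 by 4-(2-(dimethylamino)ethenyl)piperazin-1-yl in place of (1-methyl-1H-imidazol-2-yl)sulfanyl on a saturated chain carbon bound to a carbonyl carbon. Both measured steps alter the same saturated chain carbon, yet neither brings in a group resembling the incoming one, so they only show the span of numbers seen at this position. A move in either direction is plausible; the expected step of a number 6.6 percentage points higher from compound 3 to compound 4 (within the scatter) is small with wide uncertainty. Compound 4 is expected to give 50%, with a range from 25% to 80%.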

Compound 4, a percentage reported as activity, at one concentration (the size of the read-out at that concentration, not a potency): 25.8%
For compound 4 the middle estimate is 24.2 percentage points above the measured one; measured number inside the range.
By their numbers in this assay, from the lowest: compound 4; then compounds 1 and 3 (each within the scatter of the next); then compound 2.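

In this assay, for the compounds shown here, the 4-(2-(dimethylamino)ethenyl)piperazin-1-yl group is the first at this saturated chain carbon bound to a carbonyl carbon to fall beneath the chloro compound, with a number 17 percentage points lower from compound 1 to compound 4 (beyond the scatter) and with a number 17.6 percentage points lower from compound 3 to compound 4 (beyond the scatter) against the imidazolylsulfanyl compound. The largest gap at this position is now a number 57.6 percentage points lower from compound 2 to compound 4 (beyond the scatter) so this carbon shows losses as well as gains against chloro. Nothing available explains the drop.

Going by these compounds, whether the fall follows the piperazine ring or its 2-(dimethylamino)ethenyl substituent stays open. An unsubstituted piperazine or a morpholine at this carbon would separate the two.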